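Benzyl in Place of Methyl on the Lactam Nitrogen

This account rests on a few compounds, and the source may have more. Where it says the series, first, only, none or still open, it means among the compounds named here.

Measured compounds:
compound 1 `Cc1ccc2c(=O)n(C)c3c(c2c1)CCOc1ccccc1-3`, "not active" (no number reported)
compound 2 `Cc1ccc2c3c(n(C)c(=O)c2c1)-c1ccccc1OCC3`, 11.9%
compound 3 `COc1cc2c3c(n(C)c(=O)c2cc1OC)-c1ccccc1OCC3`, 98.2%

In an assay on isolated protein for inhibition of DNA topoisomerase 1 (Homo sapiens), tested at 100 uM (a higher number here means more inhibition at the concentration tested (going by the name of the read-out), a lower number less inhibition), compound 1 is reported as "not active" (no number reported), so no number places it on the scale; compound 2 gives 11.9% and compound 3 gives 98.2% in this assay. Compound 4 `COc1ccc(Cn2c3c(c4cc(C)ccc4c2=O)CCOc2ccccc2-3)cc1` has not been measured. It differs from compound 1 by 4-methoxyphenyl in place of hydrogen on a saturated chain carbon bound to an aromatic nitrogen. Going by the values given here, no measured pair isolates this change, so its effect in this assay is unknown; a modest rise in the number, possibly within the scatter, seems most plausible. Compound 4 is therefore expected to show about 20%, within 0% to 60%.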

Compound 4, a percentage reported as inhibition, at one concentration (the size of the read-out at that concentration, not a potency): "not active" (no number reported)
Compound 4 has no reported number here; no gap can be computed for the estimate.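

In this assay, going by these compounds alone, compound 1 gives "not active" (no number reported) and compound 4 gives "not active" (no number reported) with no step readable between them. From the compounds shown here alone, whether methyl to 4-methoxybenzyl changes inhibition at all stays open, and no measured evidence bears on this result.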